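Thiourea aryl substituent variation in an antiproliferative series

A few compounds are considered here, and "the series" means these few. Any claim that something is new, unique, unknown or untested is made for them only; others in the source may bear on it.

Measured compounds:
compound 1 `NC(=O)c1c(NC(=O)c2ccccc2I)sc2c1CCN(C(=S)Nc1ccccc1Cl)C2`: > 50000 nM
compound 2 `NC(=O)c1c(NC(=O)c2ccccc2I)sc2c1CCN(C(=S)Nc1ccccc1Br)C2`: > 50000 nM
compound 3 `NC(=O)c1c(NC(=O)c2ccccc2I)sc2c1CCN(C(=S)Nc1ccccc1C(F)(F)F)C2`: 49200 nM

The three compounds share one core and differ only in the group on the aromatic ring attached to the thiourea. In a functional assay on HeLa cells (Homo sapiens) for antiproliferative activity, with a stated time of 24 h (a higher number here means a weaker inhibitor, a lower number a stronger inhibitor), compound 1 reaches only the limit of the method, > 50000 nM. Compound 2 likewise gives only a limit, > 50000 nM. Among the compounds with values here, compound 3 is the sole compound with an actual number in this assay, 49200 nM, and that number sits close to the limit of > 50000 nM in this assay, at which 2 of the 3 values shown sit. The step of an at least 1.0-fold lower number from compound 1 to compound 3 (0.00 log units; that floor lies within the scatter) and the step of an at least 1.0-fold lower number from compound 2 to compound 3 (0.00 log units; that floor lies within the scatter) are therefore both floors that lie within the usual scatter, and the step that the two limits leave unreadable from compound 1 to compound 2 cannot be read at all.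

Compound 4 `COc1ccccc1NC(=S)N1CCc2c(sc(NC(=O)c3ccccc3I)c2C(N)=O)C1` carries the change (methoxy in place of trifluoromethyl on an aromatic carbon). The two readable steps, from compound 1 and from compound 2 to compound 3, show no change beyond the scatter when the group at this aromatic carbon is exchanged. No shift beyond the scatter is therefore expected from compound 3 to compound 4, a 1.0-fold higher number from compound 3 to compound 4 (0.01 log units; within the scatter). Compound 4 is estimated at 50000 nM, within 20000 nM to 125000 nM, with a strong chance that this assay again reports only a limit.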

Compound 4, half-maximal inhibitory concentration: > 50000 nM
Compound 4 was reported as a limit; the forecaster's own chance of this, stated with the estimate: 70%; the middle value sits exactly at the limit.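

In this assay compound 4 gives > 50000 nM, which is a limit and not a number. Methoxy, with one hydrogen-bond acceptor, replaces trifluoromethyl, with none, on this aromatic carbon, and the result is an at least 1.0-fold higher number from compound 3 to compound 4 (0.00 log units; that floor lies within the scatter); the steps from compound 1 and from compound 2 to compound 4 cannot be read. A group carrying oxygen at this position therefore joins chloro and bromo in giving no number, and the series remains at the ceiling of the method: the limit of > 50000 nM in this assay, at which 3 of the 4 values shown sit.

The compounds shown leave open whether an amine or a carboxylic acid on this aromatic carbon would give a value clearly away from that limit. They also leave open how far past the limit compound 1, compound 2 and compound 4 actually lie.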